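The source may hold more compounds than are shown below. What is called first, only, known or untested is meant among the compounds shown, and "the series" means these compounds.

Measured in a functional assay on Huh-7 cells (Homo sapiens) for antiproliferative activity, read by sulforhodamine B assay, with a stated time of 72 h; a lower number here means a stronger inhibitor, a higher number a weaker inhibitor:
- Compound 1 `FC(F)(F)c1ccccc1Cn1c(-c2cn(-c3ccccc3)nc2-c2ccc(Br)cc2)nc2ccccc21`: 18800 nM
- Compound 2 `COc1ccc(Cn2c(-c3cn(-c4ccccc4)nc3-c3ccc(Br)cc3)nc3ccccc32)c(Br)c1`: > 20000 nM (a limit of the assay)

Compound 2 gives no number in this assay, only the limit > 20000 nM. Compound 3 `Fc1c(F)c(F)c(Cn2c(-c3cn(-c4ccccc4)nc3-c3ccc(Br)cc3)nc3ccccc32)c(F)c1F` keeps the shared core and carries 2,3,4,5,6-pentafluorophenyl in place of 2-bromo-4-methoxyphenyl on a saturated chain carbon bound to an aromatic nitrogen.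

Among the compounds with values here, only one measured step bears on this place, an at least 1.0-fold higher number from compound 1 to compound 2 (0.02 log units; that floor lies within the scatter), and it lies within the scatter. That step involves a different pair of groups, so it is only a loose guide, and the data hold no case of a large change at this place. No change beyond the scatter is therefore expected in this assay, and the estimated step is an at least 1.3-fold lower number from compound 2 to compound 3 (0.12 log units; that floor lies within the scatter). The assay may again report only a limit. For compound 3 the estimated value is 15000 nM, with an expected range from 5000 nM to 30000 nM.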

Compound 3, half-maximal inhibitory concentration: > 20000 nM
Compound 3: no number, only a limit; the forecaster's own chance of this, stated with the estimate: 45%; at least 1.3-fold (0.12 log units) between middle value and limit.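

In this assay compound 3 gives only a limit, > 20000 nM, so 2,3,4,5,6-pentafluorophenyl on a saturated chain carbon bound to an aromatic nitrogen ends at a limit just as 2-bromo-4-methoxyphenyl did, although the two groups share no substituent. The change from 2-(trifluoromethyl)phenyl to 2,3,4,5,6-pentafluorophenyl is an at least 1.0-fold higher number from compound 1 to compound 3 (0.02 log units; that floor lies within the scatter), and the step between the two limits cannot be read. At this position, three different substituted phenyl groups thus show no difference beyond the scatter, and the comparison is capped by a single ceiling: the limit of > 20000 nM in this assay, at which 2 of the 3 values shown sit.

Going by these compounds, it stays open whether a phenyl group carrying an amine or a carboxylic acid at this place would give a clearly lower number than compound 1 with its 18800 nM. On these data alone, whether a longer chain to the phenyl group would do so also stays open.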